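A few compounds are considered here, and "the series" means these few. Any claim that something is new, unique, unknown or untested is made for them only; others in the source may bear on it.

Compound 1, `N#Cc1ccc2nc(-c3ccc(-c4ccccc4F)cc3)[nH]c2c1`; in an assay on isolated protein for inhibition of acyl-CoA desaturase 1 (Rattus norvegicus) (a higher number here means a weaker inhibitor, a lower number a stronger inhibitor), compound 1 gives > 20000 nM.
Compound 2, `CCS(=O)(=O)c1ccc2nc(-c3ccc(-c4ccccc4F)cc3)[nH]c2c1`; in this assay compound 2 gives 1250 nM.
Compound 3, `CS(=O)(=O)c1ccc2nc(-c3ccc(-c4ccc(F)cc4)cc3)[nH]c2c1`; in this assay compound 3 gives 25 nM.

The value of compound 1 is a limit of the assay, (the limit of > 20000 nM in this assay, at which 1 of the 3 values shown sits). Compound 3 stands lowest of the two numbers, with compound 2 giving the higher one. Compound 4, `CS(=O)(=O)c1ccc2nc(-c3ccc(-c4ccsc4)cc3)[nH]c2c1`, differs from compound 3 by thiophen-3-yl in place of 4-fluorophenyl on an aromatic carbon. For the measured compounds named here, the only measured step, an at least 16-fold lower number from compound 1 to compound 2 (1.20 log units; beyond the scatter), concerns a different site and does not bear on this change; compounds 2 and 3 differ in two places and give no single step. The step of a 1.6-fold higher number from compound 3 to compound 4 (0.20 log units; within the scatter) is therefore expected to stay within the scatter. Compound 4 is expected to give 40 nM, between 10 nM and 160 nM.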

Compound 4, half-maximal inhibitory concentration: 104 nM
For compound 4 the middle estimate is 2.6-fold (0.41 log units) below the measured one; measured number inside the range.
By their numbers in this assay, from the lowest: compound 3; then compound 4; then compound 2. At a limit, above all of these: compound 1.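

In this assay, for the compounds shown here, the exchange on this aromatic carbon, para to a large group, gives the first single step at this position: a 4.2-fold higher number from compound 3 to compound 4 (0.62 log units; beyond the scatter). Thiophen-3-yl therefore keeps measurable inhibition but does not match 4-fluorophenyl, as the step lies beyond the scatter, though it is modest. Nothing measured here bears on what lies behind this step.

Going by these compounds, it remains open how a pyridine ring, a carboxylic acid or an amine at this position would compare with 4-fluorophenyl. On these data alone, it is also open whether the same exchange would give a similar step with an ethylsulfonyl group in place of the methylsulfonyl group.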